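A Naphthalen-2-yl Group Replaces 2-Chlorophenyl

This account rests on a few compounds, and the source may have more. Where it says the series, first, only, none or still open, it means among the compounds named here.

Three related compounds share one core and differ in a single group: compound 1 `CO[C@@H]1[C@@H](OC)[C@H](c2ccccc2)O[C@@H]2CO[C@@H](c3cccs3)O[C@@H]12`, compound 2 `CO[C@@H]1[C@@H](OC)[C@H](c2ccccc2)O[C@@H]2CO[C@@H](c3ccc(Cl)cc3)O[C@@H]12` and compound 3 `CO[C@@H]1[C@@H](OC)[C@H](c2ccccc2)O[C@@H]2CO[C@@H](c3ccccc3Cl)O[C@@H]12`. In a functional assay on HEL cells (Homo sapiens) for cytotoxicity (a lower number here means that less compound is tolerated, a higher number that more compound is tolerated), compound 3 gives "not determined" (no result reported), so it has no number from which to start. In this assay compound 1 also gives "not determined" (no result reported). The only other entry, for compound 2, is > 50 ug/mL, which is a limit of the assay and not a number.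

The step followed here puts naphthalen-2-yl in place of 2-chlorophenyl on a saturated ring carbon, between two ring oxygen atoms, and gives compound 4 `CO[C@@H]1[C@@H](OC)[C@H](c2ccccc2)O[C@@H]2CO[C@@H](c3ccc4ccccc4c3)O[C@@H]12`. Counted, the change is naphthalen-2-yl in place of 2-chlorophenyl on a saturated ring carbon.

Within the data shown here, no measured step exists to show how such a swap behaves. Among the measured compounds shown here, the expectation in this assay is therefore no step beyond the usual scatter and no firm direction, with compound 2 at its limit of > 50 ug/mL as the sole guide. Compound 4 is expected to read about 60 ug/mL, with an estimated range from 25 ug/mL to 100 ug/mL.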

Compound 4, half-maximal cytotoxic concentration: > 50 ug/mL
Compound 4: no number, only a limit; the forecaster's own chance of this, stated with the estimate: 75%; the middle value lies beyond the limit too.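

In this assay compound 4 gives > 50 ug/mL as a limit of the assay and not a number. Among these compounds, no step from compound 2 to compound 4 can be read, because both stop at the same limit: the limit of > 50 ug/mL in this assay, at which 2 of the 4 values shown sit. The compounds shown leave open at what concentration compound 2 and compound 4 would harm these cells, and whether those concentrations differ.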